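The source may hold more compounds than are shown below. What is called first, only, known or untested is meant among the compounds shown, and "the series" means these compounds.

Measured in a functional assay on CHO cells for antagonist activity at C-C chemokine receptor type 4 (Homo sapiens), read by radioligand binding and GTPgammaS binding; on this read-out higher numbers stand for weaker inhibition and lower numbers for stronger inhibition:
compound 1 `COc1cc2c(cc1NS(=O)(=O)c1cccc(Cl)c1Cl)[nH]c(=O)n2C` gives 200 nM
compound 2 `COc1cc2c(cc1NS(=O)(=O)c1cccc(Cl)c1Cl)[nH]c(=O)n2CC(N)=O` gives 457 nM
compound 3 `CCCn1c(=O)[nH]c2cc(NS(=O)(=O)c3cccc(Cl)c3Cl)c(OC)cc21` gives 3980 nM

Compound 2 stands second highest of these three numbers: one neighbouring step is a 2.3-fold higher number from compound 1 to compound 2 (0.36 log units; beyond the scatter) and the other is an 8.7-fold higher number from compound 2 to compound 3 (0.94 log units; beyond the scatter). All three share one core and differ only in the group on the aromatic nitrogen. Compound 4 `COc1cc2c(cc1NS(=O)(=O)c1cccc(Cl)c1Cl)[nH]c(=O)n2C1CN(C(C)=O)C1` carries the change (1-acetylazetidin-3-yl in place of carbamoylmethyl on an aromatic nitrogen). Within the data shown here, two measured steps bear on this. One is the swap of the carbamoylmethyl for another group at the same place, an 8.7-fold higher number from compound 2 to compound 3 (0.94 log units; beyond the scatter); the other is the growth of the group from hydrogen to ethyl, a 20-fold higher number from compound 1 to compound 3 (1.30 log units; beyond the scatter). Both went toward higher numbers, and the group that enters here is the largest yet seen, though it keeps one hydrogen-bond acceptor as the carbamoylmethyl did. A modest rise in this assay is therefore expected, a 3.3-fold higher number from compound 2 to compound 4 (0.52 log units; beyond the scatter). For compound 4 the expected value is 1500 nM, with a range from 400 nM to 6000 nM.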

Compound 4, half-maximal inhibitory concentration: 200 nM
The estimate for compound 4 lay 7.5-fold (0.88 log units) above the measured number, and the stated range ends above it.
By their numbers in this assay, from the lowest: compounds 1 and 4 (each within the scatter of the next); then compound 2; then compound 3.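

In this assay the number at this place does not simply climb as the group on the aromatic nitrogen grows: the 1-acetylazetidin-3-yl group, with its four-membered ring, gives a 2.3-fold lower number from compound 2 to compound 4 (0.36 log units; beyond the scatter) and a 20-fold lower number from compound 3 to compound 4 (1.30 log units; beyond the scatter) even though it is larger than the propyl group. Set against the small methyl group, it shows no change at the digits printed from compound 1 to compound 4 (within the scatter), so the rise seen with propyl does not extend to every larger group. Nothing shown here gives a reason for this result.

As far as these compounds go, it stays open whether the ring or the acetyl group accounts for the result, since the two arrive together in compound 4. From the compounds shown here alone, how an azetidin-3-yl group with a free amine, or a carboxylic acid on a short chain, would read at this place also remains unknown.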